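Amide nitrogen: cyclohexyl swapped for 4-chlorobenzyl

The compounds below may be only part of what the source reports. "The series", "measured", "known", "first", "only" and "open" are said of these compounds alone.

For the measured compounds named here, compound 3 `C=CC1=C(C(=O)NC2CCCCC2)C(c2ccc(OC)cc2)OC1` is the only member with a number in a functional assay on HeLa cells (Homo sapiens) for cytotoxicity, read by MTT assay, with a stated time of 24 h (on this read-out lower numbers stand for stronger inhibition and higher numbers for weaker inhibition), where compound 3 gives 24800 nM. Compound 2 `C=CC1=C(C(=O)Nc2ccc(OCC)cc2)C(c2ccc(OC)cc2)OC1` reaches only a limit of the assay, > 100000 nM. Compound 1 `C=CC1=C(C(=O)NCc2ccc(Cl)cc2)C(c2ccc(F)cc2)OC1` likewise stops at a limit, > 100000 nM. Going by the values given here, the one measured step, an at least 4.0-fold lower number from compound 2 to compound 3 (0.60 log units; beyond the scatter), moved from the limit to a number. Compound 4 `C=CC1=C(C(=O)NCc2ccc(Cl)cc2)C(c2ccc(OC)cc2)OC1` differs from compound 3 by 4-chlorobenzyl in place of cyclohexyl on an amide-type nitrogen. Among the compounds with values here, no measured step covers this exact change; the nearest point of reference is the limit of > 100000 nM in this assay, at which 2 of the 3 values shown sit, and compound 1, which carries the same 4-chlorobenzyl on the amide nitrogen, sits at that limit. Compound 4 is therefore expected to give a higher number, a step of a 3.2-fold higher number from compound 3 to compound 4 (0.51 log units; beyond the scatter), quite possibly ending at a limit again. The estimate for compound 4 is 80000 nM, within 20000 nM to 300000 nM.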

Compound 4, half-maximal inhibitory concentration: > 100000 nM
Compound 4: no number, only a limit; the forecaster's own chance of this, stated with the estimate: 60%; middle value at least 1.2-fold (0.09 log units) away from the limit.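

In this assay, 4-chlorobenzyl in place of cyclohexyl on an amide-type nitrogen gives an at least 4.0-fold higher number from compound 3 to compound 4 (0.60 log units; beyond the scatter). Compound 3 thus remains the only member with a number, while the 4-chlorobenzyl and 4-ethoxyphenyl amides shown end at a limit: the limit of > 100000 nM in this assay, at which 3 of the 4 values shown sit. The steps from compound 2 and from compound 1 to compound 4 cannot be read, since both ends of each are limits.

On these data alone, whether a cyclopentyl ring or an n-hexyl chain on the amide-type nitrogen yields a number remains open. Also open, as far as these compounds go, is whether fluoro in place of methoxy keeps a number with cyclohexyl on that nitrogen.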